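Cyclohexyl in Place of tert-Butyl: an Expectation for Compound 4

The source may hold more compounds than are shown below. What is called first, only, known or untested is meant among the compounds shown, and "the series" means these compounds.

Of the compounds shown here, three sharing one core have been measured in an assay on HEK293 cells for displacement of a labelled ligand from NPC1-like intracellular cholesterol transporter 1 (Homo sapiens); on this read-out lower numbers stand for stronger inhibition and higher numbers for weaker inhibition. Compound 1 `CC(C)(C)OC(=O)NCCNC(=O)CN1CN(c2ccccc2)C2(CCN(C(=O)c3ccc(C(C)(C)C)cc3)CC2)C1=O` gives 10900 nM in this assay. Compound 2 `CC(C)(C)c1ccc(C(=O)N2CCC3(CC2)C(=O)N(CC(=O)NCCC(=O)O)CN3c2ccccc2)cc1` gives 11400 nM, and compound 3 `CC(C)(C)c1ccc(C(=O)N2CCC3(CC2)C(=O)N(CC(=O)NCCO)CN3c2ccccc2)cc1` gives 1000 nM. Among these three numbers compound 1 stands second highest: the step of a 1.0-fold higher number from compound 1 to compound 2 (0.02 log units; within the scatter) is within the scatter, whereas an 11-fold lower number from compound 1 to compound 3 (1.04 log units; beyond the scatter) and an 11-fold lower number from compound 2 to compound 3 (1.06 log units; beyond the scatter) are large. All three measured steps exchange the group on the saturated chain carbon two bonds along the chain from an amide-type nitrogen, and nothing else.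

Compound 4 `CC(C)(C)OC(=O)NCCNC(=O)CN1CN(c2ccccc2)C2(CCN(C(=O)c3ccc(C4CCCCC4)cc3)CC2)C1=O` is not yet measured. It differs from compound 1 at another place: cyclohexyl in place of tert-butyl on an aromatic carbon. Within the data shown here, none of the measured steps touches that aromatic carbon, so no measured step bears on this change, and the data give no guide to its direction. The expectation for compound 4 is therefore a step of no particular direction, a 1.1-fold lower number from compound 1 to compound 4 (0.04 log units; within the scatter), while a change beyond the scatter in either direction remains possible. Compound 4 is estimated at 10000 nM in this assay, within a range from 3000 nM to 35000 nM.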

Compound 4, half-maximal inhibitory concentration: 5500 nM
Beside the measured number, compound 4's estimate is 1.8-fold (0.26 log units) above it; the range from low to high includes it.
By their numbers in this assay, from the lowest: compound 3; then compounds 4, 1 and 2 (each within the scatter of the next, the first and the last beyond it).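

In this assay, the exchange of tert-butyl for cyclohexyl on an aromatic carbon, para to a large group, gives a 2.0-fold lower number from compound 1 to compound 4 (0.30 log units; within the scatter), so going from 4 to 6 heavy atoms and adding one six-membered non-aromatic ring of carbon only produces no step beyond the scatter. Among these compounds, this is the first reading at this position, since the earlier compounds differ only in the group on the saturated chain, where a change can be large, as with an 11-fold lower number from compound 1 to compound 3 (1.04 log units; beyond the scatter). The compounds shown offer no evidence on why the step at the aromatic carbon has this size.

Among the compounds shown here, it remains open whether cyclohexyl in place of tert-butyl would give a similar result with the hydroxy chain of compound 3 or the carboxy chain of compound 2, since the single step here comes from the (tert-butoxycarbonyl)amino chain of compound 1. Also open, as far as these compounds go, is how this aromatic carbon would respond to a small group such as methyl, a flat ring such as phenyl, or a cyclohexyl ring carrying an amine or a carboxylic acid.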